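Changing one phenyl group on a longer-lived compound

This account rests on a few compounds, and the source may have more. Where it says the series, first, only, none or still open, it means among the compounds named here.

In an ADME assay on microsomes from liver (Mus musculus) for metabolic stability (on this read-out higher numbers stand for a longer-lived compound and lower numbers for a shorter-lived compound), compound 1 `NS(=O)(=O)CC(=O)NCCSc1nonc1/C(=N/O)Nc1cccc(C(F)F)c1` gives 1.5 h, the highest of three measured numbers. Compound 2 `C[C@H](CSc1nonc1/C(=N/O)Nc1ccc(F)c(Br)c1)NC(=O)CS(N)(=O)=O` gives 0.537 h and compound 3 `CS(=O)(=O)NCCSc1nonc1/C(=N/O)Nc1ccc(F)c(Br)c1` gives 0.29 h, both clearly lower than compound 1. Compound 4 `N#Cc1cc(N/C(=N\O)c2nonc2SCCNC(=O)CS(N)(=O)=O)ccc1F` is still unmeasured. It keeps the rest of compound 1 but carries 3-cyano-4-fluorophenyl in place of 3-(difluoromethyl)phenyl on an amine nitrogen. Among the compounds with values here, no measured pair shows this exchange on its own, so any forecast in this assay is uncertain. The high standing of compound 1 at 1.5 h leaves more room to fall than to rise, so the expected change is a modest drop, a 1.9-fold lower number from compound 1 to compound 4 (0.27 log units; within the scatter). Compound 4 is estimated at 0.8 h, with an expected range of 0.3 h to 2 h.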

Compound 4, half-life: 2.38 h
Compound 4: middle estimate off by 3.0-fold (0.47 log units), on the low side; the whole stated range lies below it.
By their numbers in this assay, from the lowest: compounds 3 and 2 (each within the scatter of the next); then compounds 1 and 4 (each within the scatter of the next).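

In this assay, the exchange of 3-(difluoromethyl)phenyl for 3-cyano-4-fluorophenyl on the amine nitrogen makes no step beyond the scatter (a 1.6-fold higher number from compound 1 to compound 4 (0.20 log units; within the scatter)). So, on the side chain of compound 1, this position takes either ring and the half-life reads the same within the scatter. Nothing measured here explains why the two rings read alike. Still open, on these data alone, is whether an unsubstituted phenyl or a saturated ring such as cyclohexyl would read the same at this position. Also open, as far as these compounds go, is whether this exchange holds on other side chains.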